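Swapping an aryl ether for a benzyl group

The compounds below may be only part of what the source reports. "The series", "measured", "known", "first", "only" and "open" are said of these compounds alone.

Among the measured compounds shown here, compound 1 `COc1cccc(Oc2ccc3c(NCCCNCc4cc(F)ccc4OC)ccnc3c2)c1` is one of three compounds measured in an ADME assay for permeability, using PAMPA, with a stated time of 30 min, at pH 7.4 (on this read-out higher numbers stand for higher permeability and lower numbers for lower permeability), where compound 1 gives 317 10^-6 cm/s. Compound 2 `COc1cccc(Oc2ccc3c(NCCCNCc4cccc(OC)c4O)ccnc3c2)c1` gives 317 10^-6 cm/s in this assay, and the step of no change at the digits printed from compound 1 to compound 2 (within the scatter) shows that exchanging the substituent on the saturated chain carbon bound to the amine nitrogen leaves the read-out where it was. Compound 3 `FC(F)(F)c1ccc(-c2ccc3c(NCCCNCc4ccco4)ccnc3c2)cc1`, which carries a different aryl group on the shared core and a furanyl group on the chain, gives 237 10^-6 cm/s in this assay, a number that sits within the scatter of compound 1. Compound 4 `COc1ccc(F)cc1CNCCCNc1ccnc2cc(Cc3ccccc3)ccc12` differs from compound 1 at the core itself: benzyl in place of 3-methoxyphenoxy on an aromatic carbon. For the measured compounds named here, none of the measured steps touches this position; the only single-point step, from compound 1 to compound 2, concerns the chain end and was flat, and compound 3 shows that a different group on the core still gives a number within the scatter of compound 1. With all three measured values close together, the step of a 1.1-fold lower number from compound 1 to compound 4 (0.02 log units; within the scatter) is expected to stay within the scatter. Compound 4 is therefore estimated to give 300 10^-6 cm/s in this assay, with a range from 170 10^-6 cm/s to 480 10^-6 cm/s.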

Compound 4, apparent permeability: 23 10^-6 cm/s
The estimate for compound 4 lay 13-fold (1.12 log units) above the measured number, outside the stated range (below it).
By their numbers in this assay, from the lowest: compound 4; then compounds 3, 1 and 2 (each within the scatter of the next).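

Among the compounds shown here, the position on the shared core that carries 3-methoxyphenoxy is not a neutral one in this assay: benzyl in its place gives a 14-fold lower number from compound 1 to compound 4 (1.14 log units; beyond the scatter), whereas the only earlier single-point step, no change at the digits printed from compound 1 to compound 2 (within the scatter), lay at the chain end. Both groups bring one six-membered aromatic ring of carbon only, so this large step goes with a smaller exchange on paper: 9 heavy atoms and 2 hydrogen-bond acceptors leave, and 7 heavy atoms and 0 hydrogen-bond acceptors enter, while compound 3 differs from compound 1 at both the core and the chain end and so could not isolate this position. Nothing measured here gives a reason for the drop.

The compounds shown do not separate the role of the linking oxygen from that of the methoxy group, which a plain phenoxy group or a 3-methoxybenzyl group at this place would address. From the compounds shown here alone, it also stays open how other links to the same ring, such as an amine or a carbonyl, would read in this assay on this core.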